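Swapping Dimethylamino for Azido: What to Expect

This account rests on a few compounds, and the source may have more. Where it says the series, first, only, none or still open, it means among the compounds named here.

Of the compounds shown here, two have been measured so far. Compound 1 `COC/C1=C/C[C@](C)(CCC=C(C)C)/C=C/[C@@H](OC(=O)C=C(C)C)[C@](C)(OC)/C=C/C1=O` gives 9380 nM in a functional assay on SMMC-7721 cells (Homo sapiens) for antiproliferative activity, read by MTT assay, with a stated time of 48 h; a lower number here means a stronger inhibitor, a higher number a weaker inhibitor. Compound 2 `CC(C)=CCC[C@]1(C)/C=C/[C@@H](OC(=O)C=C(C)C)[C@](C)(O)/C=C/C(=O)/C(CN(C)C)=C\C1` gives 820 nM in this assay, the lowest of the two numbers shown, and the gap to compound 1 lies beyond the scatter, so compound 2 is the stronger inhibitor of the pair.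

Compound 3 `CC(C)=CCC[C@]1(C)/C=C/[C@@H](OC(=O)C=C(C)C)[C@](C)(O)/C=C/C(=O)/C(CN=[N+]=[N-])=C\C1` has not yet been measured. It differs from compound 2 in one place: azido in place of dimethylamino on a saturated chain carbon bound to a double-bonded ring carbon. Going by the values given here, no pair of measured compounds differs in exactly this way, so no measured step shows how much this exchange matters.

Among the compounds with values here, with no such step available, the expectation for the move from compound 2 to compound 3 can only be cautious: a modest weakening, a 2.4-fold higher number from compound 2 to compound 3 (0.39 log units; beyond the scatter), is expected, though a result within the scatter would not be surprising. The value of compound 3 in this assay is therefore estimated at 2000 nM, with a range from 600 nM to 7000 nM.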

Compound 3, half-maximal inhibitory concentration: 3080 nM
Beside the measured number, compound 3's estimate is 1.5-fold (0.19 log units) below it; measured number inside the range.
By their numbers in this assay, from the lowest: compound 2; then compound 3; then compound 1.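

In this assay, going by these compounds alone, azido in place of dimethylamino on a saturated chain carbon bound to a double-bonded ring carbon gives a 3.8-fold higher number from compound 2 to compound 3 (0.57 log units; beyond the scatter), the first measured step at this position, modest in size but beyond the scatter. The position therefore responds to which group sits on it, even though the two groups match in heavy atoms, hydrogen-bond donors, hydrogen-bond acceptors and net charge, so those matching counts do not by themselves hold the number in place. Why compound 3 is the weaker inhibitor of this pair remains unexplained, as no measurement here speaks to the cause.

A single exchange at this position cannot show whether dimethylamino is unusually favourable or azido mildly unfavourable, since one step gives a difference between two groups and no wider trend. A primary amine, a morpholine ring or a hydroxyl group on the same carbon, each set on the otherwise unchanged structure of compound 2, would help to separate these possibilities.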